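The compounds below may be only part of what the source reports. "The series", "measured", "known", "first", "only" and "open" are said of these compounds alone.

Compound 3 `O=C(N/N=C/c1ccco1)c1cccc(S(=O)(=O)N2CCOCC2)c1` carries a furan-2-yl group on the carbon with a double bond to nitrogen, and in a functional assay on SMMC-7721 cells (Homo sapiens) for antiproliferative activity, read by MTT assay, with a stated time of 72 h (a lower number here means a stronger inhibitor, a higher number a weaker inhibitor), compound 3 gives only a limit of the assay, > 100000 nM. Compound 1 `C/C(=N\NC(=O)c1cccc(S(=O)(=O)N2CCOCC2)c1)c1cccc(N)c1` likewise gives only a limit in this assay, > 100000 nM. Compound 2 `C/C(=N\NC(=O)c1cccc(S(=O)(=O)N2CCOCC2)c1)c1cc(Br)ccc1O` gives 2410 nM in this assay. For the measured compounds named here, the one measured step, an at least 41-fold lower number from compound 1 to compound 2 (1.61 log units; beyond the scatter), is the only change that resembles the one at hand, and it sits on (the limit of > 100000 nM in this assay, at which 2 of the 3 values shown sit). Compound 4 `COc1ccc(/C=N/NC(=O)c2cccc(S(=O)(=O)N3CCOCC3)c2)c(O)c1` is the unmeasured analogue in which the change is 2-hydroxy-4-methoxyphenyl in place of furan-2-yl on a carbon with a double bond to nitrogen. As compound 2 also carries a hydroxy group on the entering phenyl ring, the step from compound 1 to compound 2 bears on this change, and a large step toward a lower number in this assay is expected for compound 4, though its size is uncertain as compound 3 starts at a limit. Compound 4 is therefore estimated at 6000 nM, with a range of 1500 nM to 60000 nM, which means an expected step of an at least 16-fold lower number from compound 3 to compound 4 (1.22 log units; beyond the scatter).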

Compound 4, half-maximal inhibitory concentration: 3950 nM
For compound 4 the middle estimate is 1.5-fold (0.18 log units) above the measured one; low and high end bracket the measured number.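

In this assay, 2-hydroxy-4-methoxyphenyl in place of furan-2-yl gives an at least 25-fold lower number from compound 3 to compound 4 (1.40 log units; beyond the scatter), so a large step at this carbon is no longer seen in a single pair of compounds. Among the compounds shown, only compound 2 and compound 4, which both carry a hydroxy group on a phenyl ring, give numbers rather than limits, and none goes against this pattern. The full size of the new step stays unknown, as the value of compound 3 is a limit of the assay: the limit of > 100000 nM in this assay, at which 2 of the 4 values shown sit.

The compounds shown leave open whether the hydroxy group, the methoxy group or the six-membered ring itself accounts for the step. They also leave open how a phenyl ring bearing only a methoxy group, or a carboxylic acid in place of the hydroxy group, would read at this carbon.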